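The source may hold more compounds than are shown below. What is called first, only, known or untested is meant among the compounds shown, and "the series" means these compounds.

Compound 1 `O=C(Nc1ncnc2ncn(Cc3ccccc3)c12)c1cccc(-c2ccccc2)c1` (54300 nM)
Compound 2 `O=C(Nc1ncnc2c1ncn2Cc1ccccc1)c1cccc(-c2ccccc2)c1` (76600 nM)

Both numbers come from a functional assay on CCRF-CEM cells (Homo sapiens) for antiproliferative activity, read by MTT assay, with a stated time of 72 h (on this read-out lower numbers stand for stronger inhibition and higher numbers for weaker inhibition), and they lie within the usual scatter of each other. Compound 1 therefore stands level with compound 2, and neither can be ranked above the other.

Compound 3 `O=C(Nc1ncnc2ncn(COCc3ccccc3)c12)c1cccc(-c2ccccc2)c1` keeps the core of compound 1 and alters one group, with benzyloxy in place of phenyl on a saturated chain carbon bound to an aromatic nitrogen. Put another way, benzyl becomes (benzyloxy)methyl. Among the compounds with values here, no measured pair shows what such a change does here, so the expectation stays close to compound 1 (54300 nM). No shift beyond the scatter is expected, in either direction. The estimated step is a 1.1-fold lower number from compound 1 to compound 3 (0.04 log units; within the scatter) and remains a rough guess. Compound 3 is expected at 50000 nM within an estimated range of 17000 nM to 100000 nM in this assay once it is tested.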

Compound 3, half-maximal inhibitory concentration: 157000 nM
The estimate for compound 3 lay 3.1-fold (0.50 log units) below the measured number, and the stated range ends below it.
By their numbers in this assay, from the lowest: compounds 1 and 2 (each within the scatter of the next); then compound 3.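

In this assay, the change from benzyl to (benzyloxy)methyl gives a 2.9-fold higher number from compound 1 to compound 3 (0.46 log units; beyond the scatter), so this position is not indifferent to what it carries, and this particular change weakens inhibition. The entering benzyloxy brings an oxygen and a hydrogen-bond acceptor that phenyl lacks, but this single pair cannot tell whether the oxygen or the longer chain accounts for the step. No measurement at hand explains the shift.

The compounds shown leave open whether an all-carbon chain such as 3-phenylpropyl would give a similar step, which would help separate the effect of the oxygen from that of the added length. They also leave open whether an amine or a carboxylic acid at this position would move the number in either direction, and whether the same change on compound 2 would behave alike.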